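This account rests on a few compounds, and the source may have more. Where it says the series, first, only, none or still open, it means among the compounds named here.

Measured compounds in a functional assay on PC-3 cells (Homo sapiens) for antiproliferative activity, read by MTT assay, with a stated time of 48 h; on this read-out higher numbers stand for weaker inhibition and lower numbers for stronger inhibition:
compound 1, `Cc1ccc2nc(Nc3nc(Nc4ccc(S(N)(=O)=O)cc4)ncc3C)sc2c1`, gives 2710 nM.
compound 2, `NS(=O)(=O)c1ccc(Nc2ncc(F)c(Nc3nc4ccc(Cl)cc4s3)n2)cc1`, gives 1430 nM.
compound 3, `COc1ccc2nc(Nc3nc(Nc4ccc(S(N)(=O)=O)cc4)ncc3C)sc2c1`, gives only a limit of the assay, > 50000 nM.

Compound 3 therefore stands at the boundary of what this assay reports: its value is a limit and not a number, namely (the limit of > 50000 nM in this assay, at which 1 of the 3 values shown sits). Among the compounds with values here, the one measured step that reaches it is an at least 18-fold higher number from compound 1 to compound 3 (1.26 log units; beyond the scatter), a large loss on introducing methoxy at this position of the fused system.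

Compound 4, `Cc1cnc(Nc2ccc(S(N)(=O)=O)cc2)nc1Nc1nc2ccc(Cl)cc2s1`, is compound 3 with chloro in place of methoxy on an aromatic carbon. The step that bears on it is the same one, read in reverse: since methoxy cost at least that much against methyl, removing methoxy is expected to recover most of it. Compound 1, with methyl at this position, and compound 2, with chloro at this position but differing in another place on the core, give numbers within the scatter of each other, so chloro here is not expected to fall far from compound 1.

Compound 4 is expected to give 2000 nM, between 800 nM and 6000 nM. That estimate means an at least 25-fold lower number from compound 3 to compound 4 (1.39 log units; beyond the scatter), expected to be large and to bring the value back from the limit into the measurable range.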

Compound 4, half-maximal inhibitory concentration: 5400 nM
Compound 4: middle estimate off by 2.7-fold (0.43 log units), on the low side; the measured number falls inside the stated range.
By their numbers in this assay, from the lowest: compounds 2, 1 and 4 (each within the scatter of the next, the first and the last beyond it). At a limit, above all of these: compound 3.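

In this assay, chloro on this aromatic carbon of the six-membered aromatic ring of carbon only gives a measurable number where methoxy does not, with an at least 9.2-fold lower number from compound 3 to compound 4 (0.96 log units; beyond the scatter). Chloro and methyl on the same carbon do not separate, with a 2.0-fold higher number from compound 1 to compound 4 (0.30 log units; within the scatter), so among the three groups shown at this place only methoxy stands apart, and that is a reading of compound 1, compound 3 and compound 4 alone. Within the data shown here, the series also responds at a second place on the core, where methyl in place of fluoro gives a 3.8-fold higher number from compound 2 to compound 4 (0.58 log units; beyond the scatter) with chloro kept on the fused system, a change that the earlier compounds did not isolate.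

The full size of the methoxy loss stays unknown, and the step to chloro is only a bound, since the entry for compound 3 is a limit of the assay and not a number: the limit of > 50000 nM in this assay, at which 1 of the 4 values shown sits.

Also open, going by these compounds, is whether an amine, a carboxylic acid or a longer chain such as ethoxy on this aromatic carbon would fall with chloro and methyl or would go the way of methoxy.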